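A Shorter Side Chain on Three Inactive Carbamates

The compounds below may be only part of what the source reports. "The series", "measured", "known", "first", "only" and "open" are said of these compounds alone.

Compound 1 `CCC(COc1cccc(C(F)(F)F)c1)OC(=O)NCc1ccccc1`: > 100000 nM
Compound 2 `CCOC(=O)c1cccc(OCC(CC)OC(=O)NCc2ccccc2)c1`: > 100000 nM
Compound 3 `CCC(COc1cccc(NC(C)=O)c1)OC(=O)NCc1ccccc1`: > 100000 nM

In an assay for inhibition of zeta-carotene desaturase, chloroplastic/chromoplastic (Capsicum annuum), using a Dixon plot, with a stated time of 8 h (on this read-out lower numbers stand for stronger inhibition and higher numbers for weaker inhibition), compound 1 gives > 100000 nM, which is a limit of the assay and not a number. Compound 2 also sits at a limit, > 100000 nM. Compound 3 likewise reaches only a limit, > 100000 nM. Because all three sit at the limit of > 100000 nM in this assay, at which 3 of the 3 values shown sit, the steps between them carry no readable size: a step that the two limits leave unreadable from compound 1 to compound 2, a step that the two limits leave unreadable from compound 1 to compound 3 and a step that the two limits leave unreadable from compound 2 to compound 3 are all unreadable.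

Compound 4 `CC(COc1cccc(C(F)(F)F)c1)OC(=O)NCc1ccccc1` differs from compound 1 by hydrogen in place of methyl on a saturated chain carbon, two bonds along the chain from an oxygen next to a carbonyl group, leaving the trifluoromethyl ring and the carbamate untouched. Among the compounds with values here, no measured step bears on this change, since none of the measured pairs varies the chain, and the steps that do exist are themselves unreadable. With compound 1 at a limit and nothing pointing to a gain from shortening the chain, compound 4 is expected to remain at a limit as well, with the step that the limit leaves unreadable from compound 1 to compound 4 expected to be unreadable.

The estimate for compound 4 in this assay is 150000 nM, within a range of 50000 nM to 500000 nM.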

Compound 4, half-maximal inhibitory concentration: > 100000 nM
Compound 4: only a limit was reported; the forecaster's own chance of this, stated with the estimate: 85%; the middle value lies beyond the limit too.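

In this assay compound 4 gives > 100000 nM, which is a limit of the assay and not a number. No size can be read for the step between compound 1 and compound 4, as both stand at the same limit: the limit of > 100000 nM in this assay, at which 4 of the 4 values shown sit. The compounds shown leave open which structural change, if any, would bring a readable value in this assay.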